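Compound 3 after two readings at the limit

The compounds below may be only part of what the source reports. "The series", "measured", "known", "first", "only" and "open" are said of these compounds alone.

- Compound 1 `COc1ccccc1CNc1ncnc2c1ncn2[C@@H]1O[C@H](CO)[C@@H](O)[C@H]1O`: > 166000 nM (a limit, not a number)
- Compound 2 `OC[C@H]1O[C@@H](n2cnc3c(NCc4ccc(Cl)c(Cl)c4)ncnc32)[C@H](O)[C@@H]1O`: > 166000 nM (a limit, not a number)

Both entries above come from a functional assay on B16 cells (Mus musculus) for antiproliferative activity, with a stated time of 72 h; a higher number here means a weaker inhibitor, a lower number a stronger inhibitor. Among the compounds with values here, neither gives a number, so compound 2 has no exact place on the scale, and its only neighbour is no better defined. Both compounds sit at the limit of > 166000 nM in this assay, at which 2 of the 2 values shown sit.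

Compound 3 `OC[C@H]1O[C@@H](n2cnc3c(NCc4ccc(F)cc4F)ncnc32)[C@H](O)[C@@H]1O` has not yet been measured. It carries 2,4-difluorophenyl in place of 3,4-dichlorophenyl on a saturated chain carbon bound to a nitrogen on an aromatic ring. The rest of the structure is unchanged.

Within the data shown here, only one measured step bears on this change. It is a step that the two limits leave unreadable from compound 1 to compound 2, which swaps one substituted phenyl group for another at the same place. Its size cannot be read, so it offers no basis for expecting a shift in either direction in this assay. The expected outcome is a step that the limit leaves unreadable from compound 2 to compound 3, which means no change beyond the scatter. Another reading at the limit is the likeliest result.

Compound 3 is expected at about 200000 nM, with an estimated range from 100000 nM to 400000 nM.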

Compound 3, half-maximal inhibitory concentration: > 166000 nM
Compound 3 was reported as a limit; the forecaster's own chance of this, stated with the estimate: 80%; the middle value does not contradict the limit.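

In this assay compound 3 gives > 166000 nM, a limit and not a number. No step among compound 1, compound 2 and compound 3 can be read, and all three share one reading: the limit of > 166000 nM in this assay, at which 3 of the 3 values shown sit.

The compounds shown leave open how strong any of the three is in this assay, and whether changing the substituted phenyl group moves the value at all.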